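One More Methyl at the Limit of the Assay

The compounds below may be only part of what the source reports. "The series", "measured", "known", "first", "only" and "open" are said of these compounds alone.

Four compounds sharing one core are considered here: compound 1 `O=c1cc(I)n([C@@H]2O[C@H](CO)[C@@H](O)[C@H]2O)c(=O)[nH]1`, compound 2 `[N-]=[N+]=Nc1cc(=O)[nH]c(=O)n1[C@@H]1O[C@H](CO)[C@@H](O)[C@H]1O`, compound 3 `CNc1cc(=O)[nH]c(=O)n1[C@@H]1O[C@H](CO)[C@@H](O)[C@H]1O` and the still unmeasured compound 4 `CN(C)c1cc(=O)[nH]c(=O)n1[C@@H]1O[C@H](CO)[C@@H](O)[C@H]1O`. The read-out is a functional assay on MDA-MB-468 cells (Homo sapiens) for antiproliferative activity, read by WST assay, with a stated time of 3 days; a higher number here means a weaker inhibitor, a lower number a stronger inhibitor. Compound 1 gives > 50000 nM, which is a limit of the assay and not a number. Compound 2 gives > 50000 nM, which is again a limit. Compound 3 gives > 50000 nM, also a limit. Compound 3 thus has no exact number and shares its place with the other two, as shown by the limit of > 50000 nM in this assay, at which 3 of the 3 values shown sit.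

The next change turns methylamino into dimethylamino, with methyl in place of hydrogen on a nitrogen on an aromatic ring. The measured steps that bear on it are a step that the two limits leave unreadable from compound 1 to compound 3, a step that the two limits leave unreadable from compound 2 to compound 3 and a step that the two limits leave unreadable from compound 1 to compound 2. None of them offers a size to carry over, so no shift beyond the scatter is expected in either direction in this assay. The estimated change, a number no higher from compound 3 to compound 4 (the limit leaves the size open), is expected to be small. Another report of only a limit is the likeliest outcome. For compound 4 the estimate is 50000 nM, with an expected range from 25000 nM to 100000 nM.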

Compound 4, half-maximal inhibitory concentration: > 50000 nM
Compound 4: only a limit was reported; the forecaster's own chance of this, stated with the estimate: 85%; the middle value sits exactly at the limit.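

In this assay compound 4 gives > 50000 nM as a limit of the assay and not a number. No new step can be read from compound 4 to compound 1, compound 2 or compound 3, because all four share one limit: the limit of > 50000 nM in this assay, at which 4 of the 4 values shown sit. The compounds shown leave open whether any change at this place on the shared core alters antiproliferative activity.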